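A few compounds are considered here, and "the series" means these few. Any claim that something is new, unique, unknown or untested is made for them only; others in the source may bear on it.

In an assay on isolated protein for inhibition of ubiquitin carboxyl-terminal hydrolase 7 (Homo sapiens), with stated times of 30 min and 2 h (on this read-out lower numbers stand for stronger inhibition and higher numbers for weaker inhibition), compound 1 `Cn1nc2c(=O)n(CC3(O)CCN(Cc4ccc(-c5cccs5)cc4Cl)CC3)cnc2c1-c1ccc(CN)cc1` gives 38.6 nM. Among the measured compounds shown here, compound 2 `Cn1nc2c(=O)n(CC3(O)CCN(Cc4ccc(-c5cncs5)cc4Cl)CC3)cnc2c1-c1ccc(CN)cc1` gives 117 nM in this assay, and the single measured step, a 3.0-fold higher number from compound 1 to compound 2 (0.48 log units; beyond the scatter), is an exchange of one five-membered aromatic ring for another on an aromatic carbon. For the measured compounds named here, of the two numbers so far, compound 2 stands highest, with compound 1 as its only neighbour.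

Compound 3 `Cn1nc2c(=O)n(CC3(O)CCN(Cc4ccc(-c5ncco5)cc4Cl)CC3)cnc2c1-c1ccc(CN)cc1` differs from compound 2 at that same place: 1,3-oxazol-2-yl in place of 1,3-thiazol-5-yl on an aromatic carbon. The step from compound 1 to compound 2 is the only one that bears on it. It shows that exchanging the five-membered ring at this place moves the number modestly, but it gives no direction for a second exchange of this kind. A step of similar size in either direction, or none beyond the scatter, is therefore expected in this assay. Compound 3 is estimated at 100 nM, range 40 nM to 300 nM, which means a 1.2-fold lower number from compound 2 to compound 3 (0.07 log units; within the scatter).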

Compound 3, half-maximal inhibitory concentration: 1120 nM
Compound 3: the middle estimate sits 11-fold (1.05 log units) below what was measured, outside the stated range (above it).
By their numbers in this assay, from the lowest: compound 1; then compound 2; then compound 3.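

In this assay, the five-membered ring at this place, on an aromatic carbon para to a large group and meta to a chloro group, is not freely exchangeable: 1,3-oxazol-2-yl gives a 9.6-fold higher number from compound 2 to compound 3 (0.98 log units; beyond the scatter) and a 29-fold higher number from compound 1 to compound 3 (1.46 log units; beyond the scatter), which makes compound 3 the weakest of the three. The counts of heavy atoms, donors and acceptors are the same for 1,3-thiazol-5-yl and 1,3-oxazol-2-yl, so these counts do not separate compound 2 from compound 3. No supporting measurement bears on the origin of this loss.

The compounds shown leave open whether the loss follows the oxygen in the ring or the ring's point of attachment, since these two features change together in this step. A 1,3-thiazol-2-yl or 1,3-oxazol-5-yl group would separate them, and an unsubstituted phenyl ring would show whether this place needs a five-membered ring at all.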